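A few compounds are considered here, and "the series" means these few. Any claim that something is new, unique, unknown or untested is made for them only; others in the source may bear on it.

Of the compounds shown here, three that share one core have been tested in a functional assay on MCF7 cells (Homo sapiens) for antiproliferative activity, read by CCK-8 assay, with a stated time of 72 h; a lower number here means a stronger inhibitor, a higher number a weaker inhibitor. Compound 1 `O=C(Nc1cccc(-c2oc3cc(-c4ccc(F)cc4)ccc3c(=O)c2O)c1)c1ccccc1F` gives 7570 nM. Compound 2 `COc1ccc(C(=O)Nc2cccc(-c3oc4cc(-c5ccc(F)cc5)ccc4c(=O)c3O)c2)c(F)c1` gives 20000 nM, and compound 3 `Cc1cc(C)cc(C(=O)Nc2cccc(-c3oc4cc(-c5ccc(F)cc5)ccc4c(=O)c3O)c2)c1` gives 20400 nM. Compound 3 therefore carries the highest of the three numbers: against compound 2 the gap lies within the scatter, while against compound 1 it amounts to a 2.7-fold higher number from compound 1 to compound 3 (0.43 log units; beyond the scatter).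

Compound 4 `N#Cc1ccc(C(=O)Nc2cccc(-c3oc4cc(-c5ccc(F)cc5)ccc4c(=O)c3O)c2)cc1` differs from compound 3 in one place: 4-cyanophenyl in place of 3,5-dimethylphenyl on a carbonyl carbon. Two measured steps also exchange the ring on that carbonyl carbon. One is a 2.7-fold higher number from compound 1 to compound 3 (0.43 log units; beyond the scatter), a modest shift; the other is a 1.0-fold higher number from compound 2 to compound 3 (0.01 log units; within the scatter), which is no shift beyond the scatter. Exchanges of this kind have thus moved the numbers in this assay by a modest amount at most, in either direction, and a similar outcome is expected here. The expected step is a 1.7-fold lower number from compound 3 to compound 4 (0.23 log units; within the scatter), leaning toward a somewhat lower number. The estimate for compound 4 is 12000 nM, with a range from 4000 nM to 35000 nM.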

Compound 4, half-maximal inhibitory concentration: 2660 nM
Compound 4: middle estimate off by 4.5-fold (0.65 log units), on the high side; the measured number lies below the stated range.
By their numbers in this assay, from the lowest: compound 4; then compound 1; then compounds 2 and 3 (each within the scatter of the next).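

Placing 4-cyanophenyl on the carbonyl carbon gives a 7.7-fold lower number from compound 3 to compound 4 (0.88 log units; beyond the scatter) and a 7.5-fold lower number from compound 2 to compound 4 (0.88 log units; beyond the scatter), and both steps are larger than any seen among the first three compounds. The same change gives a 2.8-fold lower number from compound 1 to compound 4 (0.45 log units; beyond the scatter), so the ring on this carbonyl carbon can push the number below that of compound 1, which had been the lowest, and not only above it. No supporting measurement is available to explain this result.

From the compounds shown here alone, it remains open whether the nitrile itself matters or whether any similar group on this ring would do the same. A plain phenyl ring, or a ring carrying an amine or a carboxylic acid in place of the nitrile, would help to separate these possibilities.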